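From 2,4-dichlorophenyl to 3,4-dichlorophenyl: expectations for compound 3

A few compounds are considered here, and "the series" means these few. Any claim that something is new, unique, unknown or untested is made for them only; others in the source may bear on it.

In an ADME assay on NHDF cells (Homo sapiens) for cytotoxicity, read by MTT assay, with a stated time of 72 h (on this read-out lower numbers stand for stronger inhibition and higher numbers for weaker inhibition), compound 1 `COc1ccc(/C=C2\CCC/C(=C\c3ccc(OC)c(OC)c3)C2=O)cc1` gives 30900 nM. Compound 2 `COc1ccc(/C=C2\CCC/C(=C\c3ccc(Cl)cc3Cl)C2=O)cc1OC` gives > 50000 nM in this assay, which is a limit of the assay and not a number. Its position is therefore known only as the limit of > 50000 nM in this assay, at which 1 of the 2 values shown sits.

The next structure is compound 3 `COc1ccc(/C=C2\CCC/C(=C\c3ccc(Cl)c(Cl)c3)C2=O)cc1OC`, which has the same atoms as compound 2, joined differently: 3,4-dichlorophenyl in place of 2,4-dichlorophenyl on a double-bonded chain carbon bound to a double-bonded ring carbon. In words, 3,4-dichlorophenyl takes the place of 2,4-dichlorophenyl on a double-bonded chain carbon bound to a double-bonded ring carbon.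

For the measured compounds named here, only one measured step bears on this change: an at least 1.6-fold higher number from compound 1 to compound 2 (0.20 log units; that floor lies within the scatter). Going by the values given here, it replaced 4-methoxyphenyl with 2,4-dichlorophenyl at the same place, and no measured step yet covers a move between dichlorophenyl isomers. No step beyond the usual scatter is expected in this assay, and no direction can be assigned with confidence.

The estimated step is an at least 1.2-fold lower number from compound 2 to compound 3 (0.09 log units; that floor lies within the scatter). For compound 3 the expected value is 40000 nM, with an estimated range of 18000 nM to 70000 nM.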

Compound 3, half-maximal inhibitory concentration: 10100 nM
Beside the measured number, compound 3's estimate is 4.0-fold (0.60 log units) above it, outside the stated range (below it).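

In this assay, swapping one dichlorophenyl isomer for the other gives an at least 4.9-fold lower number from compound 2 to compound 3 (0.69 log units; beyond the scatter). The two groups are built from the same atoms and match in every count computed for them, so this position responds to how the dichlorophenyl group is arranged, which the earlier step, an at least 1.6-fold higher number from compound 1 to compound 2 (0.20 log units; that floor lies within the scatter), could not show. The new compound also separates from the methoxy-bearing compound, with a 3.1-fold lower number from compound 1 to compound 3 (0.49 log units; beyond the scatter), so a dichlorophenyl group at this place does not by itself go with a higher number, and compound 2 is the compound that goes against any reading that it lowers the number.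

On these data alone, compound 2 remains a limit of the assay and not a number, so the full size of the step from it stays open: the limit of > 50000 nM in this assay, at which 1 of the 3 values shown sits. Also open, as far as these compounds go, is whether the number keeps falling with other groups at this place, such as 4-chlorophenyl, 3,5-dichlorophenyl or a phenyl carrying a dimethylamino group, and no cause for the step can be drawn from these three compounds.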